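The source may report more compounds than this note shows. Statements on the series, on what has been measured and on what is new or still open speak of the compounds shown alone.

Measured in a functional assay on MCF7 cells (Homo sapiens) for cytotoxicity, read by sulforhodamine B assay, with a stated time of 48 h; a lower number here means a stronger inhibitor, a higher number a weaker inhibitor:
compound 1 `CCOC(=O)c1c(-c2ccc(O)cc2)c(C#N)c(=O)n(/N=C(\C)c2ccc(S(=O)(=O)N3CCCCC3)cc2)c1N` gives 25500 nM
compound 2 `CCOC(=O)c1c(-c2ccc(N(C)C)cc2)c(C#N)c(=O)n(/N=C(\C)c2ccc(S(=O)(=O)N3CCCCC3)cc2)c1N` gives 34400 nM

For the measured compounds named here, compound 2 gives the higher of these two numbers, yet its only neighbour is compound 1, and the step of a 1.3-fold higher number from compound 1 to compound 2 (0.13 log units; within the scatter) lies within the scatter, so the two cannot be told apart. Compound 3 `CCOC(=O)c1c(-c2ccc(Cl)cc2)c(C#N)c(=O)n(/N=C(\C)c2ccc(S(=O)(=O)N3CCCCC3)cc2)c1N` carries the change (chloro in place of dimethylamino on an aromatic carbon). Going by the values given here, the single step that bears on it is the earlier swap on an aromatic carbon, a 1.3-fold higher number from compound 1 to compound 2 (0.13 log units; within the scatter), which left the number within the scatter. On that basis the expected step in this assay is a 1.1-fold lower number from compound 2 to compound 3 (0.06 log units; within the scatter), nothing beyond the scatter. Compound 3 is therefore estimated at 30000 nM, within a range from 12000 nM to 75000 nM.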

Compound 3, half-maximal inhibitory concentration: 20600 nM
Compound 3: middle estimate off by 1.5-fold (0.16 log units), on the high side; measured number inside the range.
By their numbers in this assay, from the lowest: compounds 3, 1 and 2 (each within the scatter of the next).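

In this assay, chloro in place of dimethylamino (step: a 1.7-fold lower number from compound 2 to compound 3 (0.22 log units; within the scatter)) and chloro in place of hydroxy (step: a 1.2-fold lower number from compound 1 to compound 3 (0.09 log units; within the scatter)) leave all three compounds indistinguishable. Even chloro, a single atom with no hydrogen-bond donors or acceptors, therefore gives no change at this position that can be told from the scatter. No measurement shown explains why these groups read alike.

As far as these compounds go, it remains open whether a carboxylic acid, a primary amine or a longer alkyl chain here would shift the number beyond the scatter.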